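The compounds below may be only part of what the source reports. "The series", "measured", "known", "first", "only" and "open" are said of these compounds alone.

In a functional assay on HCT-116 cells (Homo sapiens) for antiproliferative activity, read by MTT assay, with a stated time of 48 h (on this read-out higher numbers stand for weaker inhibition and lower numbers for stronger inhibition), the measured compounds stand as follows:
- compound 1 `COc1cc(-c2nnc3c(OC(C)C)cc(-c4ccc5[nH]ccc5c4)cn23)cc(OC)c1OC` gives 939 nM
- compound 2 `COc1cc(-c2nnc3c(OC(C)C)cc(-c4ccc5c(ccn5C)c4)cn23)cc(OC)c1OC` gives 402 nM

Compound 2 at 402 nM holds the lower of the two numbers. Next is compound 3 `CCCN1CC(Oc2cc(-c3ccc4c(ccn4C)c3)cn3c(-c4cc(OC)c(OC)c(OC)c4)nnc23)C1` with 1-propylazetidin-3-yl in place of isopropyl on an oxygen on an aromatic ring. Among the measured compounds shown here, the only measured step (a 2.3-fold lower number from compound 1 to compound 2 (0.37 log units; beyond the scatter)) is modest and beyond the scatter, and it comes from methyl in place of hydrogen on an aromatic nitrogen. For the measured compounds named here, that step gives a rough scale but no direction for the change on the oxygen, and no measured compound varies the isopropyl. The estimated step (a 1.5-fold higher number from compound 2 to compound 3 (0.17 log units; within the scatter)) is expected to stay small, leaning toward a higher number in this assay with wide margins. For compound 3 the estimated value is 600 nM with an expected range from 150 nM to 2400 nM in this estimate.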

Compound 3, half-maximal inhibitory concentration: 675 nM
Estimate against measurement, compound 3: 1.1-fold (0.05 log units) below, within the range that was stated.
By their numbers in this assay, from the lowest: compounds 2, 3 and 1 (each within the scatter of the next, the first and the last beyond it).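

At the oxygen on an aromatic ring, going from isopropoxy to (1-propylazetidin-3-yl)oxy gives, in this assay, a 1.7-fold higher number from compound 2 to compound 3 (0.23 log units; within the scatter). This position therefore accepts a group of 7 heavy atoms with a four-membered non-aromatic ring and a hydrogen-bond acceptor in place of isopropyl, with no change beyond the scatter, whereas compounds 1 and 2 both carry isopropyl here and said nothing about this place. No supporting measurement accompanies this step, and the result carries no explanation.

Among the compounds shown here, the single step changes the ring, the nitrogen and the propyl chain together, so their separate contributions stay open. Also open, going by these compounds, is how this oxygen position responds to a 1-methylazetidin-3-yl, a piperidin-4-yl, a longer chain ending in a primary amine, or a chain ending in a carboxylic acid.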